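Bromo for Chloro on a Shared Core

The source may report more compounds than this note shows. Statements on the series, on what has been measured and on what is new or still open speak of the compounds shown alone.

Compound 1, `O=C1c2cccc([N+](=O)[O-])c2NC[C@@]12[C@H](c1ccc(Br)cc1)[C@@H](c1ccccc1)N[C@]21C(=O)Nc2ccc(Cl)cc21`: 21000 nM
Compound 2, `O=C1c2cccc([N+](=O)[O-])c2NC[C@@]12[C@H](c1ccc(Cl)cc1)[C@@H](c1ccccc1)N[C@]21C(=O)Nc2ccc(Br)cc21`: 23000 nM

Both were measured in a functional assay on HeLa cells (Homo sapiens) for cytotoxicity, read by MTT assay, with a stated time of 72 h; a lower number here means a stronger inhibitor, a higher number a weaker inhibitor. Compound 2 has the higher of the two numbers, but its gap to compound 1 lies within the usual scatter, so the two cannot be told apart. Compound 3, `O=C1c2cccc([N+](=O)[O-])c2NC[C@@]12[C@H](c1ccc(Br)cc1)[C@@H](c1ccccc1)N[C@]21C(=O)Nc2ccc(Br)cc21`, differs from compound 2 by bromo in place of chloro on an aromatic carbon. Within the data shown here, no measured pair shows this exact step, yet compound 1 and compound 2, which carry the same chloro and bromo in exchanged places, do not differ beyond scatter. The change is therefore expected to be small, with no clear direction: a 1.0-fold lower number from compound 2 to compound 3 (0.02 log units; within the scatter). Compound 3 is estimated at 22000 nM, within 11000 nM to 44000 nM.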

Compound 3, half-maximal inhibitory concentration: 25000 nM
Beside the measured number, compound 3's estimate is 1.1-fold (0.06 log units) below it; the measured number falls inside the stated range.
By their numbers in this assay, from the lowest: compounds 1, 2 and 3 (each within the scatter of the next).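

The direct steps now show that bromo in place of chloro has little effect at either halogen site in this assay. On the phenyl group, the change from 4-chlorophenyl to 4-bromophenyl gives a 1.1-fold higher number from compound 2 to compound 3 (0.04 log units; within the scatter) and at the other site the same exchange gives a 1.2-fold higher number from compound 1 to compound 3 (0.08 log units; within the scatter) so neither site shows a readable preference between these two halogens. No supporting measurement is available to explain this result. On these data alone, whether either site tolerates a different kind of group remains open. An amine or a carboxylic acid in place of the halogen could test this.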